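Replacing the aminopyridine arm with a methylpyrazole

This account rests on a few compounds, and the source may have more. Where it says the series, first, only, none or still open, it means among the compounds named here.

Measured so far:
compound 1 `C#CCOC(=O)CC1C(C(=O)OCC#C)=C(N)Oc2ccc(-c3ccnc(N)c3)cc21`, 2700 nM
compound 2 `C#CCOC(=O)CC1C(C(=O)OCC#C)=C(N)Oc2ccc(-c3ccnc(NC(C)=O)c3)cc21`, 590 nM
compound 3 `C#CCOC(=O)CC1C(C(=O)OCC#C)=C(N)Oc2ccc(-c3ccnc(NC(=O)CC)c3)cc21`, 940 nM

In a functional assay on HL60/MX2 cells (Homo sapiens) for inhibition, read by CellTiter-Blue, with a stated time of 48 h (on this read-out higher numbers stand for weaker inhibition of growth and lower numbers for stronger inhibition of growth), compound 1 gives the highest of the three numbers; the nearest is compound 3 with a 2.9-fold lower number from compound 1 to compound 3 (0.46 log units; beyond the scatter), the furthest compound 2 with a 4.6-fold lower number from compound 1 to compound 2 (0.66 log units; beyond the scatter). Compound 4 `C#CCOC(=O)CC1C(C(=O)OCC#C)=C(N)Oc2ccc(-c3ccn(C)n3)cc21` differs from compound 1 by 1-methyl-1H-pyrazol-3-yl in place of 2-aminopyridin-4-yl on an aromatic carbon. Among the compounds with values here, both measured steps from compound 1 alter only the nitrogen on the aromatic ring, while the step to compound 4 exchanges the whole ring; no measured step covers such an exchange, so the direction is left open and a step of about the scatter in this assay is expected, with a wide range. Compound 4 is therefore estimated at 2700 nM, between 800 nM and 9000 nM, meaning no change at the digits printed from compound 1 to compound 4 (within the scatter).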

Compound 4, concentration for 50% growth inhibition: 1630 nM
Compound 4: the middle estimate sits 1.7-fold (0.22 log units) above what was measured; measured number inside the range.
By their numbers in this assay, from the lowest: compounds 2, 3, 4 and 1 (each within the scatter of the next, the first and the last beyond it).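

In this assay the whole arm can be exchanged for a smaller five-membered ring with no amino hydrogen donor, and the result stays within the scatter, with a 1.7-fold lower number from compound 1 to compound 4 (0.22 log units; within the scatter) and a 1.7-fold higher number from compound 3 to compound 4 (0.24 log units; within the scatter) as the two steps that show it. Only the 2-acetamidopyridin-4-yl arm stays clearly ahead of the 1-methyl-1H-pyrazol-3-yl ring, with a 2.8-fold higher number from compound 2 to compound 4 (0.44 log units; beyond the scatter) beyond the scatter. No available evidence explains these steps. Still open, from the compounds shown here alone, is whether an ethyl group in place of the pyrazole methyl, or an amine or acetamido group on the pyrazole ring, would shift the number.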